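The source may report more compounds than this note shows. Statements on the series, on what has been measured and on what is new or still open speak of the compounds shown alone.

Of the compounds shown here, two sharing one core have been tested in an assay on CHO cells for displacement of a labelled ligand from adenosine receptor A1 (Homo sapiens), read by scintillation counting, tested at 10 uM; a higher number here means more inhibition at the concentration tested (going by the name of the read-out), a lower number less inhibition. Compound 1 `COc1ccc(-c2sc(N)c(C(=O)c3ccc(Cl)cc3)c2C)cc1` gives 1% in this assay. Within the data shown here, compound 2 `CC(C)(C)Cc1c(-c2cccnc2)sc(N)c1C(=O)c1ccc(Cl)cc1` gives 1% in this assay, which is level with compound 1 within the usual scatter of this kind of measurement; the two structures differ in more than one place, so no single step between them can be read off. Compound 3 `Cc1ccccc1-c1sc(N)c(C(=O)c2ccc(Cl)cc2)c1CC(C)(C)C` has not yet been measured. It differs from compound 2 in one place: 2-methylphenyl in place of pyridin-3-yl on an aromatic carbon. Because compound 2 gives 1% and compound 1 gives 1%, there is no sign within these numbers that any group at this place shifts the read-out, so the expected step from compound 2 to compound 3 is a number 2 percentage points higher from compound 2 to compound 3 (within the scatter), not beyond the scatter. Compound 3 is therefore estimated to give 3%, with a range from 0% to 15%.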

Compound 3, a percentage reported as inhibition, at one concentration (the size of the read-out at that concentration, not a potency): 1%
Compound 3: the middle estimate sits 2 percentage points above what was measured; the range from low to high includes it.
By their numbers in this assay, from the lowest: compounds 1, 2 and 3 (each within the scatter of the next).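

In this assay, putting 2-methylphenyl in place of pyridin-3-yl on the aromatic carbon next to the ring sulfur gives no change at the digits printed from compound 2 to compound 3 (within the scatter). Among these compounds, this is the first comparison that isolates this position, and it shows that an all-carbon ring carrying a methyl group and a ring with one nitrogen read the same here, with neither compound rising from the bottom of the scale. No measurement at hand explains this result.

As far as these compounds go, whether any group on this carbon can raise the inhibition remains open, since both groups tested here are six-membered aromatic rings, and a carboxylic acid or an aminomethyl group would be a very different kind of substituent. It is also unclear whether changing the neopentyl group or the group of 9 heavy atoms on the shared core would give a reading clearly above the scatter.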